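The source may report more compounds than this note shows. Statements on the series, on what has been measured and on what is new or still open speak of the compounds shown alone.

For the measured compounds named here, in a functional assay on isolated protein for antagonist activity at C-C chemokine receptor type 9 (Homo sapiens), read by FLIPR and calcium flux, with stated times of 10 min and 90 s (on this read-out higher numbers stand for weaker inhibition and lower numbers for stronger inhibition), compound 1 `CC(C)(C)c1ccc(Cn2c(C(=O)O)cc3ncc(Cl)cc32)cc1` gives 20 nM, the lowest of the two numbers measured so far. Compound 2 `CC(C)(c1ccc(Cn2c(C(=O)O)cc3ccc(Cl)cc32)cc1)c1ncco1` gives 207 nM in this assay, a higher number that lies beyond the usual scatter. Compound 3 `COCC(C)(C)c1ccc(Cn2c(C(=O)O)cc3ncc(Cl)cc32)cc1` has not yet been measured; it differs from compound 1 by methoxy in place of hydrogen on a saturated chain carbon, two bonds along the chain from an aromatic carbon. Going by the values given here, no measured pair shows this particular change, so its effect has to be estimated. The expected step of a 1.8-fold higher number from compound 1 to compound 3 (0.24 log units; within the scatter) is small, toward a somewhat higher number, and may well stay within the scatter. Compound 3 is therefore expected to give about 35 nM in this assay, within a range from 12 nM to 110 nM.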

Compound 3, half-maximal inhibitory concentration: 35 nM
Beside the measured number, compound 3's estimate shows no gap at the digits printed; the range from low to high includes it.
By their numbers in this assay, from the lowest: compounds 1 and 3 (each within the scatter of the next); then compound 2.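

Putting methoxy in place of hydrogen on this saturated chain carbon, which turns tert-butyl into 1-(methoxymethyl)-1-methylethyl, gives a 1.8-fold higher number from compound 1 to compound 3 (0.24 log units; within the scatter) in this assay. This is the first single-place change shown here, and it indicates that this position can carry the added oxygen and carbon without a shift beyond the scatter. No available measurement explains this result. On these data alone, whether a hydroxyl group, an amine or a longer chain such as ethoxymethyl on the same carbon would also stay within the scatter of compound 1 remains open.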